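Compound 1 and its 2,4-difluorophenyl counterpart

The compounds below may be only part of what the source reports. "The series", "measured", "known", "first", "only" and "open" are said of these compounds alone.

Among the measured compounds shown here, in a functional assay on HCT-116 cells (Homo sapiens) for inhibition, read by colorimetric assay, with a stated time of 3 days (a lower number here means a stronger inhibitor, a higher number a weaker inhibitor), compound 1 `O=C(CCCCCCNC(=O)C(O)(O)C(F)(F)F)Nc1ccncc1` gives 6670 nM, the only actual number so far. Compound 2 `O=C(CCCCCCNC(=O)C(O)C(F)(F)F)Nc1nccs1` is reported only as a limit, > 40000 nM. Compound 3 `OC(O)(c1c(F)c(F)c(-n2cc(-c3ccccc3)nn2)c(F)c1F)C(F)(F)F` is likewise reported only as a limit, > 100000 nM.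

Compound 4 `O=C(CCCCCCNC(=O)C(O)(O)C(F)(F)F)Nc1ccc(F)cc1F` differs from compound 1 in one place: 2,4-difluorophenyl in place of pyridin-4-yl on an amide-type nitrogen. For the measured compounds named here, no measured step covers this change, so the only anchor is compound 1 at 6670 nM. The step of a 1.2-fold lower number from compound 1 to compound 4 (0.08 log units; within the scatter) is expected to stay within the scatter, with no firm direction. In this assay the estimate for compound 4 is 5500 nM, with an expected range of 1800 nM to 20000 nM.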

Compound 4, half-maximal inhibitory concentration: 18500 nM
The estimate for compound 4 lay 3.4-fold (0.53 log units) below the measured number, and the stated range covers the measured number.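

In this assay, the group on the amide-type nitrogen now has its first readable step: a 2.8-fold higher number from compound 1 to compound 4 (0.44 log units; beyond the scatter). With the rest of compound 1 unchanged, 2,4-difluorophenyl in place of pyridin-4-yl therefore gives weaker inhibition, a modest change. No measured property given here bears on why the step occurs.

Still open, going by these compounds, is whether the ring nitrogen of pyridin-4-yl or the two fluorines account for the step. Plain phenyl or 4-fluorophenyl on the same nitrogen would help separate the two.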